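Chloro for ethoxy: cytotoxicity expectation for compound 4

This account rests on a few compounds, and the source may have more. Where it says the series, first, only, none or still open, it means among the compounds named here.

Compound 1 `CCOc1ccc(NC(=S)NNC(=O)c2ccncc2)cc1` is the reference point of this set. In an ADME assay on MCF-10A cells (Homo sapiens) for cytotoxicity, read by WST assay, with a stated time of 48 h (on this read-out lower numbers stand for stronger inhibition and higher numbers for weaker inhibition), compound 1 returns only a limit, > 300000 nM. Compound 2 `CCc1cccc(NC(=S)NNC(=O)c2ccncc2)c1` likewise sits at a limit in this assay, > 300000 nM. Compound 3 `Cc1cccc(C)c1NC(=S)NNC(=O)c1ccncc1` also gives a limit in this assay, > 300000 nM. Compound 1 therefore stands nowhere distinct: every value shown is the limit of > 300000 nM in this assay, at which 3 of the 3 values shown sit, and no order among compounds 1, 2 and 3 can be drawn. Compound 4 `O=C(NNC(=S)Nc1ccc(Cl)cc1)c1ccncc1` differs from compound 1 by chloro in place of ethoxy on an aromatic carbon. Among the measured compounds shown here, no measured step of this kind exists in the set, so no shift beyond the scatter is expected in either direction. The step is estimated as a number no higher from compound 1 to compound 4 (the limit leaves the size open). Compound 4 is expected at 300000 nM, between 100000 nM and 1000000 nM, most probably again reported only as a limit.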

Compound 4, half-maximal inhibitory concentration: > 300000 nM
Compound 4: no number, only a limit (the forecaster's own chance of this, stated with the estimate: 85%); the middle value lies on the limit itself.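

No step can be read from compound 1 to compound 4, because both sit at the same limit: the limit of > 300000 nM in this assay, at which 4 of the 4 values shown sit.

The compounds shown leave open any order among them, and whether chloro in place of ethoxy changes the read-out at all.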